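The compounds below may be only part of what the source reports. "The series", "measured", "known", "first", "only" and "open" are said of these compounds alone.

Compound 1 `Cc1ccc(Nc2nc(N)nc(COc3ccc4c(C)cc(=O)oc4c3)n2)cc1Cl` and compound 2 `CCc1ccc(Nc2nc(N)nc(COc3ccc4c(C)cc(=O)oc4c3)n2)cc1Cl` share one core, while compound 3 `CCc1cc(=O)oc2cc(OCc3nc(N)nc(Nc4ccc(C)cc4)n3)ccc12` and compound 4 `CCCc1cc(=O)oc2cc(OCc3nc(N)nc(Nc4ccc(C)cc4)n3)ccc12` share another; the difference between the two cores is not broken down here. In an assay on COS-7 cells for agonist activity at Free fatty acid receptor 1 (Homo sapiens), read by scintillation counting and inositol phosphate accumulation, with a stated time of 90 min (a lower number here means that less compound is needed, a higher number that more compound is needed for the effect), compound 1 gives 140 nM, and compound 2 gives 160 nM. Compound 2 differs from compound 1 by methyl in place of hydrogen on a saturated chain carbon bound to an aromatic carbon and the step was a 1.1-fold higher number from compound 1 to compound 2 (0.06 log units; within the scatter). In this assay compound 3 gives 2640 nM, the highest of the three measured numbers. Compound 4 differs from compound 3 by methyl in place of hydrogen on a saturated chain carbon, two bonds along the chain from an aromatic carbon, the same kind of change, though the place is two bonds along the chain from an aromatic carbon rather than bound to an aromatic carbon. Compound 4 has not been measured. Because the earlier step of a 1.1-fold higher number from compound 1 to compound 2 (0.06 log units; within the scatter) stayed within the scatter, a similarly small step is expected here: a 1.0-fold lower number from compound 3 to compound 4 (0.01 log units; within the scatter). In this assay compound 4 is therefore estimated at about 2600 nM, most likely between 1200 nM and 5500 nM.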

Compound 4, half-maximal effective concentration: 2900 nM
The estimate for compound 4 lay 1.1-fold (0.05 log units) below the measured number, within the range that was stated.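

In this assay the change from ethyl to propyl gives only a small step, a 1.1-fold higher number from compound 3 to compound 4 (0.04 log units; within the scatter), and it matches the earlier change from methyl to ethyl on the other core: the same change on two cores in this assay, a 1.1-fold higher number (0.06 log units; within the scatter) from compound 1 to compound 2 and a 1.1-fold higher number (0.04 log units; within the scatter) from compound 3 to compound 4, 1.0-fold (0.02 log units) apart, within the scatter of two such steps.

So, in these two pairs, adding one methyl to a short chain leaves the number in place on both cores, although the place on the chain is not the same in the two pairs. This rests on just two pairs with small steps, and it does not show that a change with a large step would carry across cores, or that the match would hold on a third core.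

On these data alone, whether a longer chain, such as butyl, would also leave the number in place remains open. So does the outcome with an amine or a carboxylic acid at the end of the chain.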